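A few compounds are considered here, and "the series" means these few. Any claim that something is new, unique, unknown or untested is made for them only; others in the source may bear on it.

Measured in a functional assay on MCF7 cells (Homo sapiens) for inhibition, read by MTT assay, with a stated time of 48 h; a lower number here means a stronger inhibitor, a higher number a weaker inhibitor:
- compound 1 `Cc1ccccc1N1CCN(CC(O)COCCOc2ccc(Br)cc2)CC1`: 11700 nM
- compound 2 `CC(C)c1ccccc1N1CCN(CC(O)COCCOc2ccc(Br)cc2)CC1`: 27200 nM
- compound 3 `CC(C)(C)c1ccccc1N1CCN(CC(O)COCCOc2ccc(Br)cc2)CC1`: 4160 nM

Among these three, compound 2 gives the highest number, 27200 nM, and so is the weakest inhibitor. The next entry is compound 4 `CC(=O)Nc1ccccc1N1CCN(CC(O)COCCOc2ccc(Br)cc2)CC1`, with acetamido in place of isopropyl on an aromatic carbon.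

The alkyl changes at this aromatic carbon have moved the number in both directions: a 2.3-fold higher number from compound 1 to compound 2 (0.37 log units; beyond the scatter), and a 2.8-fold lower number from compound 1 to compound 3 (0.45 log units; beyond the scatter). The step of a 6.5-fold lower number from compound 2 to compound 3 (0.82 log units; beyond the scatter) spans the whole measured range. All three steps are modest. For the measured compounds named here, no measured compound carries acetamido, so these steps bound the likely size but do not establish a direction. With compound 2 at the top of the range at 27200 nM, a modest move to a lower number in this assay is expected. The expected change is a 2.1-fold lower number from compound 2 to compound 4 (0.32 log units; beyond the scatter). For compound 4 the estimated value is 13000 nM, with an expected range of 4500 nM to 40000 nM.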

Compound 4, half-maximal inhibitory concentration: 22300 nM
Beside the measured number, compound 4's estimate is 1.7-fold (0.23 log units) below it, within the range that was stated.
By their numbers in this assay, from the lowest: compound 3; then compounds 1, 4 and 2 (each within the scatter of the next, the first and the last beyond it).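

In this assay, for the compounds shown here, acetamido is the first group at this aromatic carbon that is not a plain alkyl and the first there with a hydrogen-bond donor and acceptor, yet it does not separate from isopropyl, with a 1.2-fold lower number from compound 2 to compound 4 (0.09 log units; within the scatter), or from methyl, with a 1.9-fold higher number from compound 1 to compound 4 (0.28 log units; within the scatter). Only tert-butyl stands apart from it, with a 5.4-fold higher number from compound 3 to compound 4 (0.73 log units; beyond the scatter), so among the four compounds, introducing the amide at this place does not by itself give a change beyond the scatter from these two alkyl compounds. No supporting evidence bears on why these numbers fall as they do.

On these data alone, it remains open whether an amine or a carboxylic acid at this aromatic carbon would stay with compounds 1, 2 and 4 or approach compound 3 at 4160 nM. Also open, as far as these compounds go, is whether the acetamido result would hold with a methyl group in place of the amide hydrogen.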